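Fluoro in place of nitro on an aromatic carbon

The compounds below may be only part of what the source reports. "The series", "measured", "known", "first", "only" and "open" are said of these compounds alone.

Going by the values given here, in a functional assay on HeLa cells (Homo sapiens) for antiproliferative activity, read by sulforhodamine B assay, with a stated time of 48 h (on this read-out lower numbers stand for stronger inhibition and higher numbers for weaker inhibition), two compounds have numbers so far. Compound 1 (`COc1ccc2nc(-c3ccc(N/C=C\C(=O)c4ccc(OC)c(F)c4)c(C)c3)sc2c1`) gives 600 nM and compound 2 (`COc1ccc2nc(-c3ccc(N/C=C\C(=O)c4ccc(OC)c([N+](=O)[O-])c4)cc3)sc2c1`) gives 17600 nM as the higher of the two, a gap beyond the scatter. Compound 3 (`COc1ccc2nc(-c3ccc(N/C=C\C(=O)c4ccc(OC)c(F)c4)cc3)sc2c1`) has not yet been measured. It differs from compound 2 by one exchange (fluoro in place of nitro on an aromatic carbon), in which 4-methoxy-3-nitrophenyl becomes 3-fluoro-4-methoxyphenyl. Among the compounds with values here, no measured pair shows this exchange alone, so the expectation is indirect. Compound 1 also carries 3-fluoro-4-methoxyphenyl and gives 600 nM with the stronger inhibition, so a sizeable step beyond the scatter towards stronger inhibition is expected in this assay for compound 3. The estimate expects an 18-fold lower number from compound 2 to compound 3 (1.25 log units; beyond the scatter) as that step. Compound 3 is estimated at 1000 nM (expected range 250 nM to 5000 nM).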

Compound 3, half-maximal inhibitory concentration: 500 nM
Compound 3: the middle estimate sits 2.0-fold (0.30 log units) above what was measured; the measured number falls inside the stated range.
By their numbers in this assay, from the lowest: compounds 3 and 1 (each within the scatter of the next); then compound 2.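

In this assay, the exchange of nitro for fluoro ortho to a methoxy group can now be read alone, and it gives a 35-fold lower number from compound 2 to compound 3 (1.55 log units; beyond the scatter), a large step that shows how much the read-out depends on the group at this position. Hydrogen in place of methyl on an aromatic carbon, by contrast, gives a 1.2-fold lower number from compound 1 to compound 3 (0.08 log units; within the scatter), so with fluoro in place, this second exchange leaves the number within the scatter. Nothing measured here accounts for the size of the nitro-to-fluoro step.

The compounds shown leave open how an amine, a chloro group or a plain hydrogen would read at the position ortho to the methoxy group. They also leave open whether the methyl exchange would stay as small with nitro in place of fluoro.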